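This account rests on a few compounds, and the source may have more. Where it says the series, first, only, none or still open, it means among the compounds named here.

Values from an ADME assay on MT4 cells (Homo sapiens) for cytotoxicity, read by MTT assay; on this read-out higher numbers stand for lower toxicity in this test and lower numbers for higher toxicity in this test
- Compound 1 `Cc1cc(C)cc(S(=O)(=O)c2c(C(=O)NCC(=O)NCc3ccncc3)[nH]c3ccc(Cl)cc23)c1` gives > 48900 nM (a limit)
- Compound 2 `Cc1cc(C)cc(S(=O)(=O)c2c(C(=O)NC(C)C(=O)NC(C)c3ccccc3)[nH]c3ccc(Cl)cc23)c1` gives 21700 nM
- Compound 3 `Cc1cc(C)cc(S(=O)(=O)c2c(C(=O)NCC(=O)NCc3ccncn3)[nH]c3ccc(Cl)cc23)c1` gives > 48800 nM (a limit)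

In this assay compound 3 stands at > 48800 nM (a limit, not a number). Compound 4 `Cc1cc(C)cc(S(=O)(=O)c2c(C(=O)NC(C)c3cc(F)cc(F)c3)[nH]c3ccc(Cl)cc23)c1` swaps the whole chain on the amide-type nitrogen for 1-(3,5-difluorophenyl)ethyl: a group of 10 heavy atoms (8 carbon, 2 fluorine; one six-membered aromatic ring of carbon only) in place of a group of 11 heavy atoms (7 carbon, 3 nitrogen, 1 oxygen; one six-membered aromatic ring with 2 hetero atoms), on an amide-type nitrogen. Among the compounds with values here, the one measured step nearby is a step that the two limits leave unreadable from compound 1 to compound 3, which gives no size to carry over. Within the data shown here, the only true number comes from compound 2 at 21700 nM, whose chain also holds an aromatic ring of carbon only. The expected step is an at least 2.4-fold lower number from compound 3 to compound 4 (0.38 log units; beyond the scatter), an estimate pointing toward higher toxicity in this test. For compound 4 the estimated value is 20000 nM, with an expected range from 6000 nM to 50000 nM.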

Compound 4, half-maximal cytotoxic concentration: > 49700 nM
Compound 4 gave a limit, no number (the forecaster's own chance of this, stated with the estimate: 35%); at least 2.4-fold (0.39 log units) between middle value and limit.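

In this assay compound 4 gives > 49700 nM, which is a limit and not a number. Among the earlier compounds, only compound 1 and compound 3, whose chains hold a ring with hetero atoms, gave limits, so 1-(3,5-difluorophenyl)ethyl on the amide-type nitrogen shows that a ring of carbon only can give one too. Within the data shown here, the one readable step is an at least 2.2-fold higher number from compound 2 to compound 4 (0.35 log units; beyond the scatter), while the steps between the limits cannot be read.

On these data alone, whether the two fluorines matter stays open. Plain 1-phenylethyl or 1-(3,5-dichlorophenyl)ethyl at this nitrogen would test that.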